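Swapping the Sulfur-Linked Ring of Compound 2

A few compounds are considered here, and "the series" means these few. Any claim that something is new, unique, unknown or untested is made for them only; others in the source may bear on it.

Compound 2 `COc1ccc(SCc2ccc(C(=O)Nc3ccccc3N)cc2)cc1` is one of three related compounds with a shared core. In a functional assay on A-375 cells (Homo sapiens) for antiproliferative activity, read by CCK-8 assay, with a stated time of 72 h (on this read-out lower numbers stand for stronger inhibition and higher numbers for weaker inhibition), compound 2 gives 3010 nM, the second highest of the three numbers. Compound 1 `Nc1ccccc1NC(=O)/C=C/c1ccc(CSc2ccc(F)cc2)cc1` gives 3670 nM, and compound 3 `CC(C)(C)c1ccc(SCc2ccc(/C=C/C(=O)Nc3ccccc3N)cc2)cc1` gives 1550 nM. The gap from compound 2 to compound 1 lies within the scatter, and so does the gap from compound 2 to compound 3, so no order among these three can be claimed.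

Compound 4 `Cc1cc(C)cc(SCc2ccc(C(=O)Nc3ccccc3N)cc2)c1` differs from compound 2 in one place: 3,5-dimethylphenyl in place of 4-methoxyphenyl on a sulfur. Going by the values given here, no measured pair shows this exact exchange. Among the compounds with values here, the only measured step that touches the same region is the one from compound 1 to compound 3, where tert-butyl takes the place of fluoro on an aromatic carbon, giving a 2.4-fold lower number from compound 1 to compound 3 (0.37 log units; beyond the scatter). That step sits on a different core and exchanges different groups, so it is only a loose guide. Still, on that basis the change to compound 4 is expected to bring a modest lowering of the number, a 1.5-fold lower number from compound 2 to compound 4 (0.18 log units; within the scatter), rather than a large one. The estimate for compound 4 in this assay is 2000 nM, with a range from 900 nM to 4500 nM.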

Compound 4, half-maximal inhibitory concentration: 3670 nM
For compound 4 the middle estimate is 1.8-fold (0.26 log units) below the measured one; the range from low to high includes it.
By their numbers in this assay, from the lowest: compounds 3, 2, 1 and 4 (each within the scatter of the next, the first and the last beyond it).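

In this assay, the exchange on the sulfur gives a 1.2-fold higher number from compound 2 to compound 4 (0.09 log units; within the scatter), so 3,5-dimethylphenyl and 4-methoxyphenyl cannot be told apart at this position by this read-out. This pair gives a direct comparison of two rings on the sulfur with the rest of the structure held fixed, which the earlier step between compound 1 and compound 3 could not do for these groups. Both groups have the same count of heavy atoms, but the entering one has no oxygen and no hydrogen-bond acceptor, so in this one pair, removing the oxygen of the methoxy group and adding two methyl groups leaves no readable mark on the number, and nothing measured here offers an explanation for that.

As far as these compounds go, it remains open whether this holds only for rings of carbon with small groups or for a wider range of groups on the sulfur. A phenyl ring carrying an amine or a carboxylic acid, or a plain hexyl chain in place of the ring, would show whether this position responds to a more drastic exchange.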